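Aryl extension of the N-methyl analogue in the pyrrolidine series

The compounds below may be only part of what the source reports. "The series", "measured", "known", "first", "only" and "open" are said of these compounds alone.

Two compounds of this series have numbers in an assay on membranes from brain for displacement of a labelled ligand from Neuronal acetylcholine receptor; alpha4/beta2 (Rattus norvegicus); a higher number here means a weaker inhibitor, a lower number a stronger inhibitor. Compound 1 `c1cncc(N2C[C@H]3CNC[C@H]3C2)c1` gives 0.12 nM in this assay. Among the compounds with values here, compound 2 `CN1C[C@@H]2CN(c3cccnc3)C[C@@H]2C1` gives 26 nM in this assay, the higher of the two numbers; the single step of a 220-fold higher number from compound 1 to compound 2 (2.34 log units; beyond the scatter) covers the change from compound 1 to compound 2.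

Compound 3 `Cc1cccc(-c2ccc(N3C[C@H]4CN(C)C[C@H]4C3)cn2)c1` differs from compound 2 by 3-methylphenyl in place of hydrogen on an aromatic carbon. Within the data shown here, no measured step addresses a change on the aromatic ring: the one step known, from compound 1 to compound 2, concerns the amine nitrogen and says nothing about a substituent on the aromatic carbon. The expectation for compound 3 therefore rests only on the fact that the methylated core of compound 2 already sits at the weaker end of the two numbers and that the added group is large. A moderate step upward in this assay is expected, though a step within the scatter cannot be excluded.

For compound 3 the number in this assay is estimated at 70 nM (range 10 nM to 500 nM), an expected step of a 2.7-fold higher number from compound 2 to compound 3 (0.43 log units; beyond the scatter).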

Compound 3, inhibition constant: 750 nM
Compound 3: the middle estimate sits 11-fold (1.03 log units) below what was measured; the whole stated range lies below it.
By their numbers in this assay, from the lowest: compound 1; then compound 2; then compound 3.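

In this assay, within the data shown here, 3-methylphenyl in place of hydrogen on an aromatic carbon, next to the ring nitrogen and para to a group of 9 heavy atoms, gives a 29-fold higher number from compound 2 to compound 3 (1.46 log units; beyond the scatter), the first measured change on the aromatic ring. This position is therefore not indifferent to a substituent, at least for this group on the core of compound 2, and the series now shows a large upward step on the aromatic carbon as well as a 220-fold higher number from compound 1 to compound 2 (2.34 log units; beyond the scatter) at the amine nitrogen. No measurement at hand accounts for the step at this position.

At this aromatic carbon, only hydrogen and 3-methylphenyl are shown, so it remains open how an unsubstituted phenyl, a single methyl or an amine would compare on the core of compound 2. Also open, going by these compounds, is what 3-methylphenyl does on the core of compound 1, with hydrogen on the amine nitrogen, and whether the two large steps in this assay would then add.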